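An Amide Replaces the Acid: Expected Potency of Compound 4

The source may report more compounds than this note shows. Statements on the series, on what has been measured and on what is new or still open speak of the compounds shown alone.

Measured compounds and their values in a functional assay on HCT-116 cells (Homo sapiens) for inhibition, read by MTT assay, with a stated time of 72 h; a higher number here means a weaker inhibitor, a lower number a stronger inhibitor:
Compound 1 `CCOC(=O)c1oc2ccc(NS(=O)(=O)c3ccc(F)cc3)cc2c1C` gives 10500 nM.
Compound 2 `Cc1c(C(=O)O)oc2ccc(N(Cc3ccccc3)S(=O)(=O)c3ccc(Cl)cc3)cc12` gives 9130 nM.
Compound 3 `Cc1c(C(=O)O)oc2ccc(N(Cc3ccc(Cl)cc3)S(=O)(=O)c3ccc(Cl)cc3)cc12` gives 3670 nM.

Compound 3 holds the lowest number of the three. Within the data shown here, its nearest neighbour is compound 2, and the single clean step in the set, a 2.5-fold lower number from compound 2 to compound 3 (0.40 log units; beyond the scatter), is the one that separates them. Compound 1 stands further off, above compound 3 by a margin that lies beyond the usual scatter; it differs from compound 3 in several places at once, so its value cannot be tied to any one change.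

Compound 4 `Cc1c(C(=O)NCCCn2ccnc2)oc2ccc(N(Cc3ccc(Cl)cc3)S(=O)(=O)c3ccc(Cl)cc3)cc12` arises from compound 3 by the change ((3-(1H-imidazol-1-yl)propyl)amino in place of hydroxy on a carbonyl carbon). Among the measured compounds shown here, no measured step touches this position: the only step known concerns a chloro on an aromatic carbon elsewhere in the molecule, and the ester in compound 1 is confounded by other differences. With nothing to lean on, the expectation for compound 4 is a step of a 1.2-fold lower number from compound 3 to compound 4 (0.09 log units; within the scatter), that is, no change beyond the scatter, though with wide uncertainty. The estimate for compound 4 is therefore 3000 nM, expected to fall between 800 nM and 12000 nM.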

Compound 4, half-maximal inhibitory concentration: 2430 nM
Estimate against measurement, compound 4: 1.2-fold (0.09 log units) above; the measured number falls inside the stated range.
By their numbers in this assay, from the lowest: compounds 4 and 3 (each within the scatter of the next); then compounds 2 and 1 (each within the scatter of the next).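

Among these compounds, compound 3 and compound 4 give the first clean reading at this carbonyl carbon: in this assay, putting (3-(1H-imidazol-1-yl)propyl)amino in place of hydroxy gives a 1.5-fold lower number from compound 3 to compound 4 (0.18 log units; within the scatter). A single heavy atom gives way to nine, including a five-membered aromatic ring, and the two values stay within the scatter of each other, so in this pair the carboxy group can be exchanged for this carbamoyl group with no measurable loss or gain. No measurement shown here offers an explanation for this outcome.

Going by these compounds, it remains open whether the 1H-imidazol-1-yl ring matters to this result, or whether a simple methylamino group or a morpholine ring at the end of the chain would read the same. The compounds shown also leave open how a shorter or longer chain would read in this assay.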